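The source may report more compounds than this note shows. Statements on the series, on what has been measured and on what is new or still open speak of the compounds shown alone.

Measured compounds:
Compound 1, `Cc1ccc(-c2nn(-c3ccccc3)cc2-c2nc3ccccc3[nH]2)cc1`, gives 6260 nM.
Compound 2, `Cc1ccc(-c2nn(-c3ccccc3)cc2-c2nc3ccccc3n2S(=O)(=O)c2ccc(C)cc2)cc1`, gives 520 nM.
Compound 3, `Cc1ccc(-c2nn(-c3ccccc3)cc2-c2nc3ccccc3n2S(=O)(=O)c2ccc(Br)cc2)cc1`, gives 3040 nM.

In a functional assay on HepG2 cells (Homo sapiens) for antiproliferative activity, read by MTT assay, with a stated time of 24 h (a lower number here means a stronger inhibitor, a higher number a weaker inhibitor), compound 3 stands second highest of the three numbers; compound 1 lies nearest, and compound 2 furthest, with a 5.8-fold higher number from compound 2 to compound 3 (0.77 log units; beyond the scatter) separating the two sulfonyl compounds. Compound 4, `O=S(=O)(c1ccc(Br)cc1)n1c(-c2cn(-c3ccccc3)nc2-c2ccc(F)cc2)nc2ccccc21`, has not yet been measured. It differs from compound 3 by fluoro in place of methyl on an aromatic carbon, a change on the aryl ring that hangs from the shared core rather than on the sulfonyl ring. Among the measured compounds shown here, no measured step touches this position. The step of a 5.8-fold higher number from compound 2 to compound 3 (0.77 log units; beyond the scatter) exchanges methyl for a halogen on the sulfonyl ring and shows a modest loss, but it concerns another ring, and the steps of a 12-fold lower number from compound 1 to compound 2 (1.08 log units; beyond the scatter) and a 2.1-fold lower number from compound 1 to compound 3 (0.31 log units; beyond the scatter) speak only to the sulfonyl substituent itself. Without a directly comparable step, the expectation for compound 4 is a number near that of compound 3, with any shift likely within the scatter, though a modest loss as in the halogen step cannot be excluded. The estimated step is a 1.2-fold higher number from compound 3 to compound 4 (0.06 log units; within the scatter). Compound 4 is therefore expected to give 3500 nM, within 1200 nM to 10000 nM.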

Compound 4, half-maximal inhibitory concentration: 2550 nM
Compound 4: the middle estimate sits 1.4-fold (0.14 log units) above what was measured; low and high end bracket the measured number.
By their numbers in this assay, from the lowest: compound 2; then compounds 4 and 3 (each within the scatter of the next); then compound 1.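

In this assay, the first step read at this position is a 1.2-fold lower number from compound 3 to compound 4 (0.08 log units; within the scatter), so with the (4-bromophenyl)sulfonyl group kept, 4-fluorophenyl and 4-methylphenyl cannot be told apart. The earlier compounds shown here spoke only to the sulfonyl group, where bromo in place of methyl on the sulfonyl ring gave a 5.8-fold higher number from compound 2 to compound 3 (0.77 log units; beyond the scatter), beyond the scatter, whereas the exchange of methyl for fluoro on this other ring stays within it. Nothing available here accounts for this difference between the two rings.

The compounds shown leave open whether an amine or a carboxylic acid at this position would also stay within the scatter of compound 3. They also leave open whether the fluoro exchange reads the same alongside the (4-methylphenyl)sulfonyl group of compound 2.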